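Swapping the heteroaromatic amide head and mouse liver stability

A few compounds are considered here, and "the series" means these few. Any claim that something is new, unique, unknown or untested is made for them only; others in the source may bear on it.

Compound 1 `O=C(NCc1ccc(S(=O)(=O)c2ccccc2)cc1)c1nc2cnccc2[nH]1` was tested in an ADME assay on microsomes from liver (Mus musculus) for metabolic stability, read by LC-MS, with a stated time of 30 min, tested at 1 uM (on this read-out lower numbers stand for a less stable compound and higher numbers for a more stable compound), and gave 7.3%, the higher of the two numbers recorded so far. Compound 2 `O=C(NCc1ccc(S(=O)(=O)N2CCCCC2)cc1)c1cnc2nccn2c1` gave in this assay 0.28%, a number that lies within the scatter of the value of compound 1, so the two compounds cannot be told apart on stability. Compound 3 `O=C(NCc1ccc(S(=O)(=O)c2ccccc2)cc1)c1cc2cnccc2[nH]1` has not yet been measured. It differs from compound 1 at the carbonyl carbon whose other neighbour is the amide-type nitrogen: a group of 9 heavy atoms (7 carbon, 2 nitrogen; one five-membered aromatic ring with 1 hetero atom, one six-membered aromatic ring with 1 hetero atom) in place of a group of 9 heavy atoms (6 carbon, 3 nitrogen; one five-membered aromatic ring with 2 hetero atoms, one six-membered aromatic ring with 1 hetero atom), on a carbonyl carbon. Among the measured compounds shown here, with no step between measured compounds available, the author expects the change from compound 1 to compound 3 to move the percent remaining by no more than the scatter, in no clear direction, since both measured compounds sit low. The expected step is a number 0.7 percentage points higher from compound 1 to compound 3 (within the scatter). For compound 3 the estimate in this assay is 8%, between 1% and 30%.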

Compound 3, percent of the compound remaining: 54%
Beside the measured number, compound 3's estimate is 46 percentage points below it, outside the stated range (above it).
By their numbers in this assay, from the lowest: compounds 2 and 1 (each within the scatter of the next); then compound 3.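

In this assay, among the compounds shown here, the exchange on the carbonyl carbon gives a number 46.7 percentage points higher from compound 1 to compound 3 (beyond the scatter), the only step in this set and one that lies beyond the scatter. It shows that this place is not indifferent for the percent remaining: with everything else in compound 1 held fixed, a head group of 7 carbon and 2 nitrogen in place of one of 6 carbon and 3 nitrogen, at an equal count of heavy atoms, is enough to produce that step. No evidence at hand accounts for the size of the step.

On these data alone, whether the same exchange would carry over to the sulfonyl part of compound 2 remains open, since that compound differs from the others in more than one place. Also open, as far as these compounds go, is how a methyl group or a fluorine on the head group of compound 3 would read.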